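This account rests on a few compounds, and the source may have more. Where it says the series, first, only, none or still open, it means among the compounds named here.

Of the compounds shown here, two of a shared core have been measured in an ADME assay on microsomes from liver (Homo sapiens) for metabolic stability, read by LC-MS, using NADPH, with stated times of 5 min and 45 min, tested at 1 uM; on this read-out higher numbers stand for a longer-lived compound and lower numbers for a shorter-lived compound. Compound 1, `Nc1ncccc1-c1cc(Cc2ccc(OCc3ccncc3)cc2)no1`, gives 0.288 h. Compound 2, `Nc1ncccc1-c1cc(Cc2ccc(Oc3cccc(F)c3)nc2)no1`, gives 1.57 h, the higher of the two numbers; the gap between compound 1 and compound 2 lies beyond the usual scatter of repeated measurements. The next compound, compound 3, is `Nc1ncccc1-c1cc(Cc2ccc(OCC3CCC3)nc2)no1`. Its difference from compound 2 is cyclobutylmethyl in place of 3-fluorophenyl on an oxygen on an aromatic ring. Among the compounds with values here, no pair of measured compounds differs by exactly this change, so there is no measured step to lean on; the only comparison at hand, between compound 1 and compound 2, involves a different pair of groups on the same oxygen and shows only that such a swap can move this read-out well beyond the scatter. For compound 3 the expectation is a small step in this assay, a 1.7-fold lower number from compound 2 to compound 3 (0.24 log units; within the scatter), which is within the scatter or just beyond it. The estimated value for compound 3 is 0.9 h, with a range from 0.3 h to 2.5 h.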

Compound 3, half-life: 0.0775 h
The estimate for compound 3 lay 12-fold (1.06 log units) above the measured number, and the stated range ends above it.
By their numbers in this assay, from the lowest: compound 3; then compound 1; then compound 2.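

In this assay, putting cyclobutylmethyl in place of 3-fluorophenyl on an oxygen on an aromatic ring gives a 20-fold lower number from compound 2 to compound 3 (1.31 log units; beyond the scatter) and counts as a large step. Since these two compounds differ in this one place only, the step ties the change in half-life to this swap itself, which the comparison of the two earlier compounds could not do. Nothing measured here gives a reason for the size of this step.

The compounds shown leave open whether a plain phenyl, a benzyl or a cyclobutyl on the same oxygen would give a number closer to that of compound 2 or to that of compound 3. As far as these compounds go, whether the fluorine on the ring contributes to the longer half-life of compound 2 also remains open.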